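This account rests on a few compounds, and the source may have more. Where it says the series, first, only, none or still open, it means among the compounds named here.

Measured in a functional assay on HBL-100 cells (Homo sapiens) for antiproliferative activity, read by luminescence and CellTiter-Glo, with a stated time of 48 h; on this read-out lower numbers stand for stronger inhibition and higher numbers for weaker inhibition:
Compound 1 `O=C1CCC[C@@H]([C@H]2C[C@@H]2c2ccccc2)O1`: > 100000 nM, a limit.
Compound 2 `O=C1C=CC[C@@H](/C=C/C2CCCCC2)O1`: 48200 nM.
Compound 3 `O=C1C=CC[C@H](/C=C/c2ccc([N+](=O)[O-])cc2)O1`: 6700 nM.

Of the two actual numbers in this assay, the higher belongs to compound 2, at 48200 nM. The nearest is compound 3 at 6700 nM, a gap beyond the usual scatter. The result for compound 1 is a limit and not a number.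

Compound 4 `O=C1C=CC[C@H](/C=C/C2CCCCC2)O1` is the next compound to consider: the two compounds have the same atoms and bonds and differ only in configuration as drawn: 1 of 2 stereo elements differ; a stereocentre at a saturated ring carbon is drawn S in compound 2 and R in compound 4. For the measured compounds named here, no measured pair here shows what such an inversion does. A moderate step towards a lower number is therefore expected in this assay, though with little confidence, and a step within the scatter remains possible. The estimated change is a 1.7-fold lower number from compound 2 to compound 4 (0.24 log units; within the scatter). For compound 4 the expected value is 28000 nM, with an estimated range of 9000 nM to 85000 nM.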

Compound 4, half-maximal inhibitory concentration: 29000 nM
Compound 4: middle estimate off by 1.0-fold (0.02 log units), on the low side, within the range that was stated.
By their numbers in this assay, from the lowest: compound 3; then compounds 4 and 2 (each within the scatter of the next). At a limit, above all of these: compound 1.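

In this assay, the inversion of the stereocentre at a saturated ring carbon gives a 1.7-fold lower number from compound 2 to compound 4 (0.22 log units; within the scatter), the first measured step of this kind in the set. The pair can be read as a test of configuration alone for one reason: the fact that compounds 2 and 4 differ only in the configuration as drawn. For this pair, then, the configuration as drawn at this stereocentre does not separate the two compounds on this read-out.

As far as these compounds go, it remains open whether the same inversion would stay as small in compounds carrying an amine or a carboxylic acid on the side chain.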